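The compounds below may be only part of what the source reports. "The series", "measured", "known", "first", "only" and "open" are said of these compounds alone.

Measured so far in an ADME assay on HEK293 cells (Homo sapiens) for cytotoxicity, read by resazurin assay, with a stated time of 48 h; a higher number here means that more compound is tolerated, a lower number that less compound is tolerated:

compound 1 `O=S(=O)(Nc1ccc(-c2nc3ccccc3o2)cc1)c1ccc(F)c(C(F)(F)F)c1` gives 82000 nM
compound 2 `O=S(=O)(Nc1ccc2oc(-c3ccccc3)nc2c1)c1ccccc1O` gives 33000 nM
compound 3 `COc1ccc(S(=O)(=O)Nc2ccc(-c3nc4ccccc4o3)cc2)cc1` gives > 100000 nM

The value for compound 3 is a limit of the assay and not a number, since it sits at the limit of > 100000 nM in this assay, at which 1 of the 3 values shown sits. Compound 3 thus stands at the edge of what this assay can report, while compound 1 and compound 2 both give numbers inside the measured range. Compound 2 carries a 2-hydroxyphenyl group on a sulfonyl sulfur, though on a core joined differently from that of compound 3, and its value shows that this group can sit well inside the measured range.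

Compound 4 `O=S(=O)(Nc1ccc(-c2nc3ccccc3o2)cc1)c1ccccc1O` has not yet been measured. It differs from compound 3 in one place: 2-hydroxyphenyl in place of 4-methoxyphenyl on a sulfonyl sulfur. For the measured compounds named here, no step between measured compounds covers this change, so its size in this assay is open. The pair of compound 2 and compound 3 suggests that somewhat less of compound 4 may be tolerated than of compound 3, a step probably beyond the scatter but not a large one.

Compound 4 is therefore expected to give about 55000 nM in this assay, with a likely range from 20000 nM to 100000 nM. This corresponds to an expected step of an at least 1.8-fold lower number from compound 3 to compound 4 (0.25 log units; that floor lies within the scatter).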

Compound 4, half-maximal cytotoxic concentration: > 100000 nM
Compound 4 gave a limit, no number (the forecaster's own chance of this, stated with the estimate: 35%); middle value at least 1.8-fold (0.25 log units) away from the limit.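

In this assay compound 4 gives > 100000 nM, which is a limit and not a number. Compound 3 gives > 100000 nM, likewise a limit. No step can be read from these two limits for compound 3 and compound 4: the limit of > 100000 nM in this assay, at which 2 of the 4 values shown sit.

The compounds shown leave open how much 2-hydroxyphenyl in place of 4-methoxyphenyl on a sulfonyl sulfur changes the tolerated concentration.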